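Shortening the hydroxamate chain of compound 2

The compounds below may be only part of what the source reports. "The series", "measured", "known", "first", "only" and "open" are said of these compounds alone.

Compound 1 `COc1ccc2c(c1)c(CC(=O)O)c(C)n2Cc1ccc(-c2cn(CCCCCCC(=O)NO)nn2)cc1` gives 22 nM in an assay on isolated protein for inhibition of protein deacetylase HDAC6 (Homo sapiens), with a stated time of 20 h; on this read-out higher numbers stand for weaker inhibition and lower numbers for stronger inhibition.
Compound 2 `COC(=O)Cc1c(C)n(Cc2ccc(-c3cn(CCCCCCCC(=O)NO)nn3)cc2)c2ccc(OC)cc12` gives 5 nM in this assay.
Compound 3 `Cc1ccc(-c2cc(C(=O)NCCCCCC(=O)NO)nn2-c2ccc(S(N)(=O)=O)cc2)cc1` gives 92 nM in this assay.

Among these three, compound 2 stands at the lowest number in this assay, and so at the strongest inhibition. Compound 1 is its nearest neighbour, yet the gap between compound 1 and compound 2 lies beyond the usual scatter; compound 3 is furthest away, with a gap that also lies well beyond it. All three carry a hydroxamic acid at the end of a saturated chain.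

Compound 4 `COC(=O)Cc1c(C)n(Cc2ccc(-c3cn(CCCCCC(=O)NO)nn3)cc2)c2ccc(OC)cc12` keeps the core and the methyl ester of compound 2 and alters only the chain: hydroxycarbamoyl in place of 2-(hydroxycarbamoyl)ethyl on a saturated chain carbon, five bonds along the chain from an aromatic nitrogen. Among the compounds with values here, no pair of measured compounds shows this same change, so there is no measured step to lean on. Since the chain that carries the hydroxamic acid becomes shorter, and since the shorter-chained compound 1 already sits above compound 2, a rise in the number is expected, which would mean weaker inhibition: the step from compound 2 to compound 4 is estimated at an 8.0-fold higher number from compound 2 to compound 4 (0.90 log units; beyond the scatter). Compound 4 is therefore expected to give about 40 nM in this assay, with a range from 10 nM to 160 nM.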

Compound 4, half-maximal inhibitory concentration: 6830 nM
Estimate against measurement, compound 4: 170-fold (2.23 log units) below; measured number outside the range, above it.
By their numbers in this assay, from the lowest: compound 2; then compound 1; then compound 3; then compound 4.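

The change from 2-(hydroxycarbamoyl)ethyl to hydroxycarbamoyl, on a saturated chain carbon, five bonds along the chain from an aromatic nitrogen, produces in this assay a large step: a 1400-fold higher number from compound 2 to compound 4 (3.14 log units; beyond the scatter). This is the first pair among the compounds shown that differs in this one place, with the core and the methyl ester held constant, and so the first to isolate the length of the chain carrying the hydroxamic acid. It shows that this change alone can move the read-out from strong inhibition to the weakest inhibition of the set, a sensitivity that the earlier compounds, which differ in more than one place, could not reveal, and no measurement at hand accounts for a step of this size.

With only two chain lengths on this core and ester, the compounds shown leave open whether the number changes gradually or abruptly across a chain of intermediate length, and whether a longer chain than that of compound 2 would lower it or raise it. They also leave open whether the same shortening would have a step of similar size with a carboxylic acid in place of the methyl ester.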